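Trifluoromethyl in place of tert-butyl on the shared core

The source may hold more compounds than are shown below. What is called first, only, known or untested is meant among the compounds shown, and "the series" means these compounds.

Compound 1 `COc1cc(-c2ccnc3cc(-c4ccc(C)cc4)nn23)cc(OC)c1OC` gives 21 nM in a functional assay on HeLa cells (Homo sapiens) for inhibition, read by CCK-8 assay, with a stated time of 48 h; on this read-out lower numbers stand for stronger inhibition and higher numbers for weaker inhibition. Compound 3 `COc1cc(-c2ccnc3cc(-c4ccc(C)c(C)c4)nn23)cc(OC)c1OC` gives 241 nM in this assay, a step of an 11-fold higher number from compound 1 to compound 3 (1.06 log units; beyond the scatter). Compound 2 `COc1cc(-c2ccnc3cc(-c4ccc(C(C)(C)C)cc4)nn23)cc(OC)c1OC` reaches only the limit of > 10000 nM in this assay, at which 1 of the 3 values shown sits, in this assay, reported as > 10000 nM, so no number is known for it. The step of an at least 470-fold higher number from compound 1 to compound 2 (2.67 log units; beyond the scatter) and the step of an at least 41-fold lower number from compound 2 to compound 3 (1.61 log units; beyond the scatter) show that changing the group on the six-membered aromatic ring of carbon only moves the read-out strongly. Compound 4 `COc1cc(-c2ccnc3cc(-c4ccc(C(F)(F)F)cc4)nn23)cc(OC)c1OC` differs from compound 2 by trifluoromethyl in place of tert-butyl on an aromatic carbon. Compound 2 stands at a limit, so only a downward step can show. A large downward step is expected, an at least 6.6-fold lower number from compound 2 to compound 4 (0.82 log units; beyond the scatter). Compound 4 is therefore expected near 1500 nM, in the range 150 nM to 10000 nM.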

Compound 4, half-maximal inhibitory concentration: 1840 nM
Estimate against measurement, compound 4: 1.2-fold (0.09 log units) below; measured number inside the range.
By their numbers in this assay, from the lowest: compound 1; then compound 3; then compound 4. At a limit, above all of these: compound 2.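

In this assay the change gives an at least 5.4-fold lower number from compound 2 to compound 4 (0.73 log units; beyond the scatter) although both groups count the same heavy atoms, so heavy-atom count alone does not set the read-out at this position. Even so, methyl keeps the lower number, with an 88-fold higher number from compound 1 to compound 4 (1.94 log units; beyond the scatter) in the change to trifluoromethyl, and the 3,4-dimethylphenyl group does too, with a 7.6-fold higher number from compound 3 to compound 4 (0.88 log units; beyond the scatter) in the change to 4-(trifluoromethyl)phenyl. As far as these compounds go, compound 2 remains a limit and not a number, so the size of the first step stays open-ended: the limit of > 10000 nM in this assay, at which 1 of the 4 values shown sits.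

The compounds shown leave open how hydrogen, chlorine, a methoxy group or an amine would read at this place on the ring.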